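The source may report more compounds than this note shows. Statements on the series, on what has been measured and on what is new or still open speak of the compounds shown alone.

Within the data shown here, compound 2, `CSc1nc(NCc2ccc([Se]C)cc2)c2ccccc2n1`, is the only compound in this set with a numerical result in a functional assay on CCRF-CEM cells (Homo sapiens) for cytotoxicity, read by MTT assay, with a stated time of 72 h; on this read-out lower numbers stand for stronger inhibition of growth and higher numbers for weaker inhibition of growth: it gives 63300 nM. Compound 1, `COc1ccc(CNc2nc([Se]C)nc3ccccc23)cc1`, reaches only the assay limit of > 100000 nM, which is a bound rather than a measurement; (the limit of > 100000 nM in this assay, at which 1 of the 2 values shown sits). Compound 3, `COc1ccc(CNc2nc(SC)nc3ccccc23)cc1`, has not been measured yet and differs from compound 2 by a group of 2 heavy atoms (1 carbon, 1 oxygen; no ring) in place of a group of 2 heavy atoms (1 carbon, 1 selenium; no ring), on an aromatic carbon. Among the measured compounds shown here, no measured pair shows this exact change, so the expectation rests on the weak potencies seen so far: the estimated move is a 1.9-fold higher number from compound 2 to compound 3 (0.28 log units; within the scatter), toward weaker inhibition, beyond the usual scatter. Compound 3 is therefore estimated at 120000 nM, within 40000 nM to 400000 nM.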

Compound 3, concentration for 50% growth inhibition: 93700 nM
Estimate against measurement, compound 3: 1.3-fold (0.11 log units) above; the range from low to high includes it.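

In this assay, placing methoxy instead of the selenium-bearing group on an aromatic carbon, para to a large group, gives a 1.5-fold higher number from compound 2 to compound 3 (0.17 log units; within the scatter), so the two groups cannot be told apart at this position. The sulfur-for-selenium change in the other group gives an at least 1.0-fold lower number from compound 1 to compound 3 (0.02 log units; that floor lies within the scatter). Compound 1 sits at an assay limit, so this step is only a floor: the limit of > 100000 nM in this assay, at which 1 of the 3 values shown sits.

The compounds shown leave open whether an amine, a carboxylic acid or a longer chain at the para position would give a clearly lower number.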